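Chloro to hydroxy on the core of compound 1

The source may hold more compounds than are shown below. What is called first, only, known or untested is meant among the compounds shown, and "the series" means these compounds.

Working notes on a small series, with two compounds measured and one pending. In a functional assay on cells (Erythrocyte, Rattus norvegicus) for inhibition, read by hemolysis, with a stated time of 1 h (on this read-out higher numbers stand for weaker inhibition and lower numbers for stronger inhibition), compound 1 (`COc1cc(OC)c(-c2cc(=O)c3cc(Cl)ccc3o2)cc1OC`) gives 2.13 ug/mL. Compound 2 (`COc1cc(OC)c(C(=O)/C=C/c2cc(OC)c(OC)cc2OC)c(OC)c1`) gives 2.13 ug/mL. Compound 1 therefore stands level with compound 2 at the digits shown, within the scatter. Among the measured compounds shown here, the two structures do not form a single-place pair, so the series offers no measured step to guide the next reading.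

Compound 3 (`COc1cc(OC)c(-c2cc(=O)c3cc(O)ccc3o2)cc1OC`) keeps the core of compound 1 and carries hydroxy in place of chloro on an aromatic carbon. The nearest anchor is compound 1 at 2.13 ug/mL. For the measured compounds named here, with no measured step available, the expectation in this assay is a change no larger than the scatter, with no firm direction, and a wide range is kept to reflect this thin basis. The estimate corresponds to an expected 1.2-fold higher number from compound 1 to compound 3 (0.07 log units; within the scatter). For compound 3 the estimated value is 2.5 ug/mL, with an expected range from 1 ug/mL to 6 ug/mL.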

Compound 3, half-maximal inhibitory concentration: 2.14 ug/mL
Estimate against measurement, compound 3: 1.2-fold (0.07 log units) above; the range from low to high includes it.
By their numbers in this assay, from the lowest: compounds 1, 2 and 3 (each within the scatter of the next).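

Among the compounds shown here, the step from chloro to hydroxy is the first single-place comparison: in this assay, it reads a 1.0-fold higher number from compound 1 to compound 3 (0.00 log units; within the scatter). At this aromatic carbon, meta and para to a fused ring, replacing the chlorine atom with an oxygen atom and bringing in the hydrogen-bond donor and acceptor counted for hydroxy leaves the reading within the scatter, so this assay does not separate these two groups at this place on the shared core. No supporting measurement is available to explain why the two groups read alike here.

As far as these compounds go, with only chloro and hydroxy compared, it remains open whether this level reading extends to groups of another kind at the same carbon, such as an amine, a carboxylic acid or a longer chain like butoxy. From the compounds shown here alone, it is also open whether the same exchange would read alike at another place on the core, or with the methoxy groups of the attached ring replaced, since a single step at one carbon speaks only for that carbon.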